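Swapping methyl for fluoro on an aromatic carbon

The source may hold more compounds than are shown below. What is called first, only, known or untested is meant among the compounds shown, and "the series" means these compounds.

Values in a functional assay on HCT-116 cells (Homo sapiens) for antiproliferative activity, with a stated time of 72 h; a higher number here means a weaker inhibitor, a lower number a stronger inhibitor:
Compound 1 `O=C(COc1ccc(CN2CC=C(c3c[nH]c4cccc(F)c34)CC2)c(F)c1)NO` gives 1220 nM
Compound 2 `O=C(COc1ccc(CN2CC=C(c3c[nH]c4ccc(F)cc34)CC2)cc1)NO` gives 949 nM
Compound 3 `Cc1ccc2[nH]cc(C3=CCN(Cc4ccc(OCC(=O)NO)cc4F)CC3)c2c1` gives 1450 nM

These three values lie within the usual scatter of one another, so compound 3 1450 nM cannot be ranked against compound 1 or compound 2 in this assay.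

The next compound is compound 4 `O=C(COc1ccc(CN2CC=C(c3c[nH]c4ccc(F)cc34)CC2)c(F)c1)NO`, which has fluoro in place of methyl on an aromatic carbon. This turns 5-methyl-1H-indol-3-yl into 5-fluoro-1H-indol-3-yl.

Among the measured compounds shown here, one measured step bears on this group. It is a 1.2-fold higher number from compound 1 to compound 3 (0.08 log units; within the scatter), where 5-methyl-1H-indol-3-yl replaced 4-fluoro-1H-indol-3-yl, and it stays within the scatter. Compound 2 also carries 5-fluoro-1H-indol-3-yl and gives 949 nM, though it differs from compound 4 elsewhere.

No shift beyond the scatter is therefore expected, and the estimated step is a 1.3-fold lower number from compound 3 to compound 4 (0.10 log units; within the scatter).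

Compound 4 is expected at 1150 nM, with an estimated range of 620 nM to 2100 nM.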

Compound 4, half-maximal inhibitory concentration: > 5000 nM
Compound 4 was reported as a limit; the forecaster's own chance of this, stated with the estimate: 1%; middle value at least 4.3-fold (0.63 log units) away from the limit.
By their numbers in this assay, from the lowest: compounds 2, 1 and 3 (each within the scatter of the next). At a limit, above all of these: compound 4.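

Compound 4 gives > 5000 nM in this assay as a limit of the assay, not a number. All three steps to it lie beyond the scatter: an at least 3.4-fold higher number from compound 3 to compound 4 (0.53 log units; beyond the scatter) for fluoro in place of methyl, an at least 5.2-fold higher number from compound 2 to compound 4 (0.72 log units; beyond the scatter) for the added fluoro, and an at least 4.0-fold higher number from compound 1 to compound 4 (0.61 log units; beyond the scatter) for 5-fluoro-1H-indol-3-yl in place of 4-fluoro-1H-indol-3-yl. The earlier compounds could not be ranked, yet among these four the 5-fluoro-1H-indol-3-yl group is tolerated in compound 2, which lacks the added fluoro, while that added fluoro is tolerated in compound 1 and compound 3, so only their combination in compound 4 stands apart.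

The limit leaves the true size of these steps open, and the compounds shown give no reason for them. Also open, from the compounds shown here alone, is how chloro or an amine on this aromatic carbon would behave alongside the added fluoro.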